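Propoxycarbonyl to isopropylcarbamoyl in the platelet series

The source may hold more compounds than are shown below. What is called first, only, known or untested is meant among the compounds shown, and "the series" means these compounds.

Values in a functional assay on cells (Platelet, Homo sapiens) for inhibition; a lower number here means a stronger inhibitor, a higher number a weaker inhibitor:
- compound 1 `CCOC(=O)c1ccc(-c2nn(Cc3ccccc3OC)c3ccccc23)cc1`: 470 nM
- compound 2 `CCOC(=O)c1ccc(-c2nn(Cc3ccc(OC)cc3)c3ccccc23)cc1`: 620 nM
- compound 3 `CCCOC(=O)c1ccc(-c2nn(Cc3ccccc3)c3ccccc23)cc1`: > 10000 nM

Compound 3 has no numerical value and stands only at the limit of > 10000 nM in this assay, at which 1 of the 3 values shown sits. Any step away from compound 3 therefore starts from a limit and not from a number.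

Compound 4 `CC(C)NC(=O)c1ccc(-c2nn(Cc3ccccc3)c3ccccc23)cc1` keeps the rest of compound 3 and changes one group: isopropylamino in place of propoxy on a carbonyl carbon. In words, this is isopropylamino in place of propoxy on a carbonyl carbon, or propoxycarbonyl to isopropylcarbamoyl.

Among the measured compounds shown here, the only measured step is a 1.3-fold higher number from compound 1 to compound 2 (0.12 log units; within the scatter). That change sits on a saturated chain carbon bound to an aromatic nitrogen, not on the carbonyl carbon, so it gives only weak guidance here. For the measured compounds named here, no measured step covers a change on the carbonyl carbon, and the size of this one stays open. The working expectation is a reading for compound 4 near the limit in this assay, with a real chance of no number at all. The estimated change is small and uncertain in direction: an at least 1.2-fold lower number from compound 3 to compound 4 (0.09 log units; that floor lies within the scatter). In this assay the expected value for compound 4 is 8000 nM, within an estimated range from 1500 nM to 20000 nM.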

Compound 4, half-maximal inhibitory concentration: > 10000 nM
Compound 4 was reported as a limit; the forecaster's own chance of this, stated with the estimate: 50%; middle value at least 1.2-fold (0.09 log units) from the limit.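

In this assay compound 4 gives > 10000 nM, a limit and not a number. Compound 3 is also a limit, so the step between compound 3 and compound 4 cannot be read: the limit of > 10000 nM in this assay, at which 2 of the 4 values shown sit.

The compounds shown leave open the size and direction of any effect of isopropylamino in place of propoxy on a carbonyl carbon.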